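The source may report more compounds than this note shows. Statements on the series, on what has been measured and on what is new or still open speak of the compounds shown alone.

Compound 1 `COC(=O)c1nc(C)n(-c2ccccc2)n1` in a functional assay on NCI-H226 cells (Homo sapiens) for inhibition, read by MTT assay, with a stated time of 72 h (on this read-out lower numbers stand for stronger inhibition of growth and higher numbers for weaker inhibition of growth), gives > 100000 nM, which is a limit of the assay rather than a number.
Compound 2 `COC(=O)c1nc(C)n(-c2ccc(C(F)(F)F)cc2)n1` gives 16600 nM.
Compound 3 `COC(=O)c1nc(C)n(-c2ccc(F)cc2)n1` gives 11700 nM.

Compound 3 holds the lowest of the two numbers, but the step of a 1.4-fold lower number from compound 2 to compound 3 (0.15 log units; within the scatter) lies within the scatter, so the two cannot be ordered. Against the limit of compound 1 the step of an at least 8.5-fold lower number from compound 1 to compound 3 (0.93 log units; beyond the scatter) is clear.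

Compound 4 `CCc1nc(C(=O)OC)nn1-c1ccc(F)cc1` differs from compound 3 by methyl in place of hydrogen on a saturated chain carbon bound to an aromatic carbon. The measured steps of an at least 6.0-fold lower number from compound 1 to compound 2 (0.77 log units; beyond the scatter) and an at least 8.5-fold lower number from compound 1 to compound 3 (0.93 log units; beyond the scatter) changed the group on the aromatic ring, not this chain, so none bears directly on the new change. No step beyond the scatter is expected: a 1.1-fold lower number from compound 3 to compound 4 (0.03 log units; within the scatter). Compound 4 is therefore estimated at 11000 nM, between 4000 nM and 35000 nM.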

Compound 4, concentration for 50% growth inhibition: 71300 nM
The estimate for compound 4 lay 6.5-fold (0.81 log units) below the measured number; the whole stated range lies below it.
By their numbers in this assay, from the lowest: compounds 3 and 2 (each within the scatter of the next); then compound 4. At a limit, above all of these: compound 1.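

Going from methyl to ethyl at this place gives a 6.1-fold higher number from compound 3 to compound 4 (0.78 log units; beyond the scatter) in this assay, the first change on this chain, and it moves the number the opposite way from the earlier steps on the aromatic ring. A single added carbon here is therefore enough to weaken growth inhibition clearly. Compound 4 also stands closer to the top of what this assay can read: the limit of > 100000 nM in this assay, at which 1 of the 4 values shown sits.

From the compounds shown here alone, whether a longer chain such as propyl weakens inhibition further stays open. So does whether an amine on this chain would behave like the added methyl.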